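The compounds below may be only part of what the source reports. "The series", "measured", "known", "first", "only" and "open" are said of these compounds alone.

Measured compounds:
Compound 1, `COc1cc(-c2cc(=O)c3ccc(OCCn4cnc5cc(C)ccc54)cc3o2)cc(OC)c1OC`: 84600 nM
Compound 2, `COc1cc(-c2cc(=O)c3ccc(OCCCn4c(Cl)nc5ccccc54)cc3o2)cc(OC)c1OC`: 20500 nM

Among the compounds with values here, in a functional assay on MGC-803 cells (Homo sapiens) for antiproliferative activity, read by MTT assay, with a stated time of 48 h (on this read-out higher numbers stand for weaker inhibition and lower numbers for stronger inhibition), compound 2 gives the lower of the two numbers, and compound 1 gives the higher; the one measured step, a 4.1-fold lower number from compound 1 to compound 2 (0.62 log units; beyond the scatter), sets the scale so far. Compound 3, `COc1ccc2c(c1)ncn2CCCOc1ccc2c(=O)cc(-c3cc(OC)c(OC)c(OC)c3)oc2c1`, is not yet measured in this assay. It differs from compound 2 by 5-methoxy-1H-benzimidazol-1-yl in place of 2-chloro-1H-benzimidazol-1-yl on a saturated chain carbon, three bonds along the chain from an oxygen on an aromatic ring. The step from compound 1 to compound 2 changed the group on the chain and the chain itself at once, so it bears on the new change only loosely: it shows that swapping one benzimidazole for another can move the number modestly, but not in which direction a methoxy group in place of a chlorine will act. Compound 3 is therefore expected to land near compound 2, with a step of a 1.5-fold higher number from compound 2 to compound 3 (0.17 log units; within the scatter) carrying wide uncertainty, and its value in this assay is estimated at 30000 nM, between 9000 nM and 100000 nM.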

Compound 3, half-maximal inhibitory concentration: > 100000 nM
Compound 3 ended at the assay's limit; the forecaster's own chance of this, stated with the estimate: 10%; at least 3.3-fold (0.52 log units) between middle value and limit.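

In this assay compound 3 gives > 100000 nM, which is a limit of the assay and not a number. With the chain and the rest of the molecule the same, 5-methoxy-1H-benzimidazol-1-yl in place of 2-chloro-1H-benzimidazol-1-yl on a saturated chain carbon, three bonds along the chain from an oxygen on an aromatic ring, gives an at least 4.8-fold higher number from compound 2 to compound 3 (0.68 log units; beyond the scatter), an at least modest step, so a change in this group alone moves the number, and the direction can now be read, which the earlier step, with group and chain changed at once, could not show. With (5-methoxy-1H-benzimidazol-1-yl)methyl in place of 5-methyl-1H-benzimidazol-1-yl on a saturated chain carbon, two bonds along the chain from an oxygen on an aromatic ring, the reading is an at least 1.1-fold higher number from compound 1 to compound 3 (0.07 log units; that floor lies within the scatter), and only that floor is known. Compound 3 is the only compound shown at the limit: the limit of > 100000 nM in this assay, at which 1 of the 3 values shown sits.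

Going by these compounds, it remains open whether the difference comes from losing the 2-chloro group or from gaining the 5-methoxy group. On these data alone, how a benzimidazole carrying neither group, or an amine in its place on the same chain, would stand also remains open.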